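Series notes: hydrogen in place of methoxy

The source may report more compounds than this note shows. Statements on the series, on what has been measured and on what is new or still open speak of the compounds shown alone.

Two members of the series carry numbers. Compound 1 `COc1ccc(-c2[nH]c3ccccc3c2/C=C(\C#N)S(=O)(=O)c2ccccc2)cc1` gives in a functional assay on BT-549 cells (Homo sapiens) for inhibition, read by sulforhodamine B assay, with a stated time of 48 h (a lower number here means a stronger inhibitor of growth, a higher number a weaker inhibitor of growth), 1600 nM. Compound 2 `CCOC(=O)C(=Cc1c(-c2ccccc2)[nH]c2ccccc12)C(=O)OCC` gives in this assay 5300 nM. Compound 1 thus stands lowest of the two numbers; compound 2, its nearest neighbour, lies higher by a gap that is beyond the usual scatter. Going by the values given here, compound 2 differs from compound 1 in more than one place, so no single step between measured compounds is available, and nothing can be said about the effect of any one change from these two values alone.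

Compound 3 `N#C/C(=C\c1c(-c2ccccc2)[nH]c2ccccc12)S(=O)(=O)c1ccccc1` differs from compound 1 in one place only: hydrogen in place of methoxy on an aromatic carbon of a six-membered aromatic ring of carbon only, para to a large group. Among the compounds with values here, for this change the series holds no measured step. The step is expected to be modest, toward a weaker inhibitor of growth, and possibly within the scatter, a 1.6-fold higher number from compound 1 to compound 3 (0.19 log units; within the scatter). Within the data shown here, the anchor is compound 1 because 1600 nM is the only number for the shared core with this side chain. Compound 3 is therefore estimated at 2500 nM in this assay, with a range from 800 nM to 8000 nM.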

Compound 3, concentration for 50% growth inhibition: 11600 nM
Compound 3: the middle estimate sits 4.6-fold (0.67 log units) below what was measured, outside the stated range (above it).
By their numbers in this assay, from the lowest: compound 1; then compound 2; then compound 3.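

In this assay, going by these compounds alone, the first measured step at this position reads a 7.3-fold higher number from compound 1 to compound 3 (0.86 log units; beyond the scatter), for hydrogen in place of methoxy on an aromatic carbon, para to a large group. With the rest of the structure held constant, 4-methoxyphenyl to phenyl moves the series toward a weaker inhibitor of growth by a margin beyond the scatter, so this place on the ring clearly bears on the read-out, at least for the side chain of compound 1. Nothing at hand speaks to the origin of the step, which stands as an observation on this single pair of compounds.

As far as these compounds go, whether the step is particular to methoxy remains open, and a hydroxyl, an ethoxy, a fluorine or an amine on the same aromatic carbon would show how far other groups at this place track with it. Also open, from the compounds shown here alone, is whether 4-methoxyphenyl in place of phenyl would shift the number in the same direction and to a similar extent when carried on the side chain of compound 2.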